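Pyrrolidine Urea in Place of Oxolane Amide

The source may hold more compounds than are shown below. What is called first, only, known or untested is meant among the compounds shown, and "the series" means these compounds.

Compound 2 `O=C(C1CCCO1)N1CCc2nc(C#Cc3ccccc3)sc2C1` is the only one of the three measured compounds to yield a number in an assay on HEK293 cells for positive allosteric modulation of metabotropic glutamate receptor 5 (Homo sapiens), read by FLIPR, with a stated time of 1 h; a higher number here means that more compound is needed for the effect, a lower number that less compound is needed: compound 2 gives 790 nM. Compound 1 `Cc1cccc(C#Cc2nc3c(s2)C(=O)NCC3)c1` gives only a limit in this assay, > 10000 nM. Compound 3 `O=S(=O)(N1CCCCC1)N1CCc2nc(C#Cc3ccccc3)sc2C1` likewise reaches only a limit, > 10000 nM. Two of the three values therefore sit at the limit of > 10000 nM in this assay, at which 2 of the 3 values shown sit, and compound 2 stands alone as the single measurable point in the set.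

Compound 4 `O=C(N1CCCC1)N1CCc2nc(C#Cc3ccccc3)sc2C1` has not yet been measured. It differs from compound 2 in one place: pyrrolidin-1-yl in place of oxolan-2-yl on a carbonyl carbon. The carbonyl and the amide-type nitrogen in the ring are kept; only the group on the far side of the carbonyl is exchanged. Among the compounds with values here, no step between measured compounds shows how a change of this kind moves this assay, so the expectation rests on compound 2 alone. The step expected is a 1.9-fold higher number from compound 2 to compound 4 (0.28 log units; within the scatter), a modest shift that may well stay within the usual scatter. Compound 4 is accordingly estimated at 1500 nM, with a range from 500 nM to 5000 nM.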

Compound 4, half-maximal effective concentration: 9.8 nM
Estimate against measurement, compound 4: 150-fold (2.18 log units) above; the whole stated range lies above it.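

The group on this carbonyl carbon has a strong hold on the read-out: in this assay, pyrrolidin-1-yl in place of oxolan-2-yl gives an 81-fold lower number from compound 2 to compound 4 (1.91 log units; beyond the scatter), although the two rings are both five-membered and non-aromatic, with the same count of heavy atoms. The exchange puts a ring nitrogen in place of the oxygen and attaches the ring to the carbonyl carbon through that nitrogen, so a small change in atoms at this place is enough for a large step. The compounds shown give no reason for the size of this step.

They leave open whether the ring nitrogen at the point of attachment or the loss of the oxygen carries the step. Nor do they show whether a ring is needed here at all, which a dimethylamino group on the same carbonyl carbon would address.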